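Fluorine removal from the benzyl group in a weak series

The source may report more compounds than this note shows. Statements on the series, on what has been measured and on what is new or still open speak of the compounds shown alone.

Going by the values given here, compound 1 `Fc1ccccc1Cn1nnc2c(NC3CC3)nc(-c3ccccc3)nc21` is the weaker of the two compounds measured so far: in an assay on isolated protein for binding affinity to adenosine receptor A1 (Bos taurus) (a higher number here means a weaker inhibitor, a lower number a stronger inhibitor), compound 1 gives 15000000 nM, the highest number of the pair. Among the compounds with values here, its nearest neighbour is compound 2 `CCCCNc1nc(-c2ccccc2)nc2c1nnn2Cc1ccccc1F`, which in this assay gives 4300000 nM; the only measured step, a 3.5-fold lower number from compound 1 to compound 2 (0.54 log units; beyond the scatter), comes with butyl in place of cyclopropyl on a nitrogen on an aromatic ring.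

Compound 3 `c1ccc(Cn2nnc3c(NC4CC4)nc(-c4ccccc4)nc32)cc1` differs from compound 1 at a different site: hydrogen in place of fluoro on an aromatic carbon. Cut one bond further out this reads 2-fluorobenzyl to benzyl, on an aromatic carbon of a six-membered aromatic ring of carbon only. Within the data shown here, no measured step touches this part of the shared core; the step from compound 1 to compound 2 concerns the substituent on the ring nitrogen and gives no guidance here. With nothing in the data pointing either way, the expected step in this assay is none beyond the scatter, so no change at the digits printed from compound 1 to compound 3 (within the scatter) is the estimate. Compound 3 is therefore expected to give about 15000000 nM in this assay, with a range from 5000000 nM to 45000000 nM.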

Compound 3, inhibition constant: 11000000 nM
Estimate against measurement, compound 3: 1.4-fold (0.13 log units) above; the measured number falls inside the stated range.
By their numbers in this assay, from the lowest: compound 2; then compounds 3 and 1 (each within the scatter of the next).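

In this assay, the step from 2-fluorobenzyl to benzyl is a 1.4-fold lower number from compound 1 to compound 3 (0.13 log units; within the scatter), so hydrogen and fluoro on this aromatic carbon, ortho to a large group, cannot be told apart, and compound 3 at 11000000 nM stands level with compound 1 at 15000000 nM. Going by these compounds alone, the fluoro is therefore not needed to hold the value in this cyclopropyl-bearing compound, and within this pair the benzyl position shows no response to this change, whereas the butyl for cyclopropyl swap, a 3.5-fold lower number from compound 1 to compound 2 (0.54 log units; beyond the scatter), remains the only step beyond the scatter. No available evidence bears on this result.

From the compounds shown here alone, whether a larger or differently built group on the same aromatic carbon, such as chloro, methoxy or an amine, would also leave the number in place remains open, since fluoro and hydrogen are the only two substituents compared there. Also open, going by these compounds, is whether removing the fluoro gives the same result with butyl on the nitrogen, or with a longer chain or a carboxylic acid in that place.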